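The compounds below may be only part of what the source reports. "The series", "measured", "known", "first", "only" and "open" are said of these compounds alone.

In a functional assay on SMMC-7721 cells (Homo sapiens) for cytotoxicity, read by MTT assay, with a stated time of 4 days (a lower number here means a stronger inhibitor, a higher number a weaker inhibitor), compound 1, with the structure `C=C1C[C@]23C[C@@]1(O)CC[C@H]2c1cc(Br)c(O)c(C)c1[C@@H]3Cn1cc(-c2ccc(Cl)cc2)nn1`, gives 19100 nM. For the measured compounds named here, compound 2, with the structure `C=C1C[C@]23C[C@@]1(O)CC[C@H]2c1ccc(O)c(C)c1[C@@H]3Cn1cc(-c2ccc(F)cc2)nn1`, differs from it in two places and so no single step between the two can be read. For compound 2 this assay returns only a limit of > 20000 nM, not a number. That limit is one of two values shown, as noted in the limit of > 20000 nM in this assay, at which 1 of the 2 values shown sits, so where compound 2 stands can be said only as weaker than the top of the measured range. Compound 3, with the structure `C=C1C[C@]23C[C@@]1(O)CC[C@H]2c1ccc(O)c(C)c1[C@@H]3Cn1cc(-c2ccc(Cl)cc2)nn1`, carries one change from compound 2: chloro in place of fluoro on an aromatic carbon. Going by the values given here, since no measured pair shows this change alone, the expectation for this assay is a step of no clear direction and of a size that stays within the usual scatter, written as a step that the limit leaves unreadable from compound 2 to compound 3. Compound 3 is therefore expected to give about 25000 nM, estimated between 12000 nM and 60000 nM, with a real chance that only a limit is reported again.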

Compound 3, half-maximal inhibitory concentration: > 20000 nM
Compound 3 gave a limit, no number (the forecaster's own chance of this, stated with the estimate: 55%); the middle value is on the limit's open side.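

Changing 4-fluorophenyl to 4-chlorophenyl gives no readable result in this assay, where compound 2 and compound 3 both return a limit rather than a number, and the step between them cannot be read: the limit of > 20000 nM in this assay, at which 2 of the 3 values shown sit.

For the compounds shown here, compound 3 does supply the first comparison of compounds differing in one place that can be read, with hydrogen in place of bromo on an aromatic carbon: an at least 1.0-fold higher number from compound 1 to compound 3 (0.01 log units; that floor lies within the scatter). This step is only a floor, so it does not show whether the bromo matters in this assay.

From the compounds shown here alone, how far compound 2 and compound 3 lie beyond their limits remains open, and with it any real difference between fluoro and chloro at this position. Also open, going by these compounds, is how an amine or a carboxylic acid at this position on the phenyl ring would read in this assay.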